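Swapping the ester for a chlorinated aryl on the saturated carbon

The compounds below may be only part of what the source reports. "The series", "measured", "known", "first", "only" and "open" are said of these compounds alone.

Measured so far:
Compound 1, `O=S(=O)(c1ccc(Cl)cc1)N1Cc2c[nH]nc2CC1c1nccs1`: 54%
Compound 2, `O=S(=O)(c1ccc(Cl)cc1)N1Cc2c[nH]nc2CC1c1ccccc1`: 5%
Compound 3, `CCOC(=O)C1Cc2n[nH]cc2CN1S(=O)(=O)c1ccc(Cl)cc1`: 8%

Of the compounds shown here, three on one shared core have been tested in an ADME assay on microsomes from liver (Homo sapiens) for metabolic stability, using NADPH, with a stated time of 30 min, in the presence of a further agent that is not named here; a lower number here means that less of the compound is left, a higher number that more of the compound is left. Compound 1 gives 54%, compound 2 gives 5%, and compound 3 gives 8%. Compound 3 stands second highest of the three numbers, its nearest neighbour being compound 2, while compound 1 sits far above it; the step of a number 46 percentage points lower from compound 1 to compound 3 (beyond the scatter) is large, whereas the step of a number 3 percentage points higher from compound 2 to compound 3 (within the scatter) lies within the scatter.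

Compound 4, `O=S(=O)(c1ccc(Cl)cc1)N1Cc2c[nH]nc2CC1c1ccc(Cl)cc1`, has not yet been measured in this assay. It differs from compound 3 in one place: 4-chlorophenyl in place of ethoxycarbonyl on a saturated ring carbon. Among the measured compounds shown here, the steps that bear on this change are a number 49 percentage points lower from compound 1 to compound 2 (beyond the scatter) and a number 3 percentage points higher from compound 2 to compound 3 (within the scatter); the first shows that an aromatic carbon ring on that saturated ring carbon gives a low number, and the second shows that the ethoxycarbonyl of compound 3 and the phenyl of compound 2 land in the same low region. Compound 4 carries a 4-chlorophenyl, closest in kind to the phenyl of compound 2, so only a step within the scatter is expected, a number 1 percentage points lower from compound 3 to compound 4 (within the scatter). Compound 4 is therefore estimated at 7%, with a range from 0% to 22%.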

Compound 4, percent of the compound remaining: 12%
Beside the measured number, compound 4's estimate is 5 percentage points below it, within the range that was stated.
By their numbers in this assay, from the lowest: compounds 2, 3 and 4 (each within the scatter of the next); then compound 1.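

In this assay, the 4-chlorophenyl on the saturated ring carbon stays in the same low region as the ethoxycarbonyl it replaces, with a number 4 percentage points higher from compound 3 to compound 4 (within the scatter), so this exchange of an open-chain ester for a chlorinated aromatic ring does not separate the two compounds. The new information is that adding chloro in place of hydrogen on an aromatic carbon of the phenyl also leaves the read-out in that region, with a number 7 percentage points higher from compound 2 to compound 4 (within the scatter). The gap to the 1,3-thiazol-2-yl group persists with this substituted phenyl, as shown by a number 42 percentage points lower from compound 1 to compound 4 (beyond the scatter), so among the four compounds shown, only compound 1 stands apart from the low group formed by compound 2, compound 3 and compound 4.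

No measurement at hand accounts for the separate standing of the 1,3-thiazol-2-yl group. Going by these compounds, it remains open whether another aromatic ring containing nitrogen, such as pyridin-2-yl or 1,3-oxazol-2-yl, would stand with compound 1 or with the low group, and where an amine or a carboxylic acid on the same saturated ring carbon would fall.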